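Extending the chain on the amide-type nitrogen of compound 2

The source may report more compounds than this note shows. Statements on the series, on what has been measured and on what is new or still open speak of the compounds shown alone.

Compound 2 `COc1c(C)cnc(CN2CC(=O)N(CC(C)C)c3c(Cl)nc(N)nc32)c1C` gives 70 nM in a functional assay on MCF7 cells (Homo sapiens) for inhibition (a higher number here means a weaker inhibitor, a lower number a stronger inhibitor), the lowest of the three numbers recorded so far. Going by the values given here, compound 1 `Cc1cnc(CN2CC(=O)N(CC(C)C)c3c(Cl)nc(N)nc32)c(C)c1Br` gives 280 nM in this assay; the step of a 4.0-fold lower number from compound 1 to compound 2 (0.60 log units; beyond the scatter) is the only change measured in one place within the set. Compound 3 `COc1c(C)cnc(CN2c3nc(N)nc(Cl)c3NC(=O)[C@@H]2C)c1C` gives 940 nM in this assay; it differs from compound 2 in more than one place, so its value shows only that this altered arrangement of the shared core sits well above compound 2.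

Compound 4 `COc1c(C)cnc(CN2CC(=O)N(CCCC(C)C)c3c(Cl)nc(N)nc32)c1C` carries isopentyl in place of isopropyl on a saturated chain carbon bound to an amide-type nitrogen in a ring. Among the compounds with values here, no measured step touches this position: the step from compound 1 to compound 2 concerns a group on an aromatic carbon, and compound 3 is not a single-point comparison. The isobutyl group is the same in compounds 1 and 2, which says nothing about whether a longer chain is tolerated. The change adds no donors, acceptors or charge, and nothing among the three measured compounds argues for a large step. On these data alone, the expectation for compound 4 is therefore a step of a 1.4-fold higher number from compound 2 to compound 4 (0.15 log units; within the scatter) that lies within the scatter, with a wide range because the position is untested. In this assay compound 4 is estimated at 100 nM, with a range from 30 nM to 350 nM.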

Compound 4, half-maximal inhibitory concentration: 3110 nM
Estimate against measurement, compound 4: 31-fold (1.49 log units) below; measured number outside the range, above it.
By their numbers in this assay, from the lowest: compound 2; then compound 1; then compound 3; then compound 4.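

The nitrogen substituent of compound 2 is not a neutral site in this assay: isopentyl in place of isopropyl on a saturated chain carbon bound to an amide-type nitrogen in a ring gives a 44-fold higher number from compound 2 to compound 4 (1.65 log units; beyond the scatter), a large step and a bigger one than the change on the aromatic carbon, a 4.0-fold lower number from compound 1 to compound 2 (0.60 log units; beyond the scatter). Going by these compounds alone, the groups that leave and enter differ only in carbon count, with no ring, hydrogen-bond donors, hydrogen-bond acceptors or net charge on either side, so within this pair the loss goes with chain extension alone, and this position now has a measured sensitivity that the earlier compounds could not reveal. Nothing available on this pair accounts for the size of the step.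

Two chain lengths cannot show whether the number climbs gradually or abruptly with length, or whether an ethyl or cyclopropylmethyl group would match or improve on compound 2. On these data alone, it also remains open whether a chain of similar length ending in a hydroxyl group or an amine would keep the number of compound 2 or follow compound 4.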